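The source may hold more compounds than are shown below. What is called first, only, known or untested is meant among the compounds shown, and "the series" means these compounds.

Compound 1 `CCCC(=O)N1CCC(c2cc(OC)ccc2N)=N1`: 13.1%
Compound 2 `COc1ccc(N)c(C2=NN(C(=O)C3CCCCC3)CC2)c1`: 13.3%

In an assay on isolated protein for inhibition of Nitric oxide synthase, inducible (Homo sapiens), with a stated time of 30 min, tested at 1 mM (on this read-out lower numbers stand for less inhibition and higher numbers for more inhibition at the one concentration tested (going by the name of the read-out)), compound 2 gives 13.3%, and compound 1 with 13.1% sits within the scatter of it, so the two stand together. Compound 3 `COc1ccc(N)c(C2=NN(C(=O)CCc3ccccc3)CC2)c1` differs from compound 2 in one place: phenethyl in place of cyclohexyl on a carbonyl carbon. Among the compounds with values here, the only measured step, a number 0.2 percentage points higher from compound 1 to compound 2 (within the scatter), altered the same group on the carbonyl carbon and stayed within the scatter, so it bears on this change only loosely. Compound 3 is therefore expected to show no step beyond the scatter, a number 0.7 percentage points higher from compound 2 to compound 3 (within the scatter). The estimate for compound 3 is 14%, within 3% to 28%.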

Compound 3, a percentage reported as inhibition, at one concentration (the size of the read-out at that concentration, not a potency): 21.2%
The estimate for compound 3 lay 7.2 percentage points below the measured number; measured number inside the range.
By their numbers in this assay, from the lowest: compounds 1, 2 and 3 (each within the scatter of the next).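

In this assay the carbonyl carbon now carries a group with an aromatic ring, and the numbers still do not separate: a number 7.9 percentage points higher from compound 2 to compound 3 (within the scatter), and a number 8.1 percentage points higher from compound 1 to compound 3 (within the scatter). Neither phenethyl for cyclohexyl nor phenyl for methyl on the chain takes the read-out beyond the scatter. Nothing further is available that bears on this result. Going by these compounds, it remains open whether an amine or a carboxylic acid on that chain, or a longer chain ending in phenyl, would give a step beyond the scatter.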